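The compounds below may be only part of what the source reports. "The series", "measured", "known", "first", "only" and "open" are said of these compounds alone.

Compound 1, with the structure `O=C(NCc1cc(C(F)(F)F)cc(C(F)(F)F)c1)c1cnc2ccccc2c1-c1ccccc1`, is tested in an assay on CHO cells for displacement of a labelled ligand from Substance-P receptor (Homo sapiens), with a stated time of 90 min (on this read-out lower numbers stand for stronger inhibition and higher numbers for weaker inhibition), and gives 208 nM. Compound 2, with the structure `CN(Cc1cc(C(F)(F)F)cc(C(F)(F)F)c1)C(=O)c1cnc2ccccc2c1-c1ccccc1`, is its methylated counterpart and in this assay compound 2 gives 92 nM. The difference between these two is methyl in place of hydrogen on an amide-type nitrogen, and the step it made was a 2.3-fold lower number from compound 1 to compound 2 (0.35 log units; beyond the scatter).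

Compound 3, with the structure `Cc1c(C(=O)NCc2cc(C(F)(F)F)cc(C(F)(F)F)c2)c(-c2ccccc2)cc2nnnn12`, carries the same bis(trifluoromethyl)benzyl amide on a different core; how the two cores differ from compound 1 is not broken down here. In this assay compound 3 gives 279 nM. Against compound 1 the two values lie within the usual scatter of each other, so no order is read between them, while the value of compound 2 is lower than that of compound 3.

Compound 4, with the structure `Cc1c(C(=O)N(C)Cc2cc(C(F)(F)F)cc(C(F)(F)F)c2)c(-c2ccccc2)cc2nnnn12`, has not yet been measured. It differs from compound 3 by methyl in place of hydrogen on an amide-type nitrogen, the same change, at the same kind of place, that turned compound 1 into compound 2. For compound 4 the step from compound 3 is expected to be about a 2.3-fold lower number from compound 3 to compound 4 (0.37 log units; beyond the scatter) in this assay, an expectation resting on the size of the step seen in a 2.3-fold lower number from compound 1 to compound 2 (0.35 log units; beyond the scatter) and on nothing more, since the change occurs only twice among these compounds. On that basis compound 4 is estimated at 120 nM, with a likely range from 50 nM to 300 nM.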

Compound 4, half-maximal inhibitory concentration: 57 nM
Beside the measured number, compound 4's estimate is 2.1-fold (0.32 log units) above it; the range from low to high includes it.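

Placing methyl on the amide nitrogen of the core of compound 3 gave, in this assay, a 4.9-fold lower number from compound 3 to compound 4 (0.69 log units; beyond the scatter), so the number fell on this core as it had on the core of compound 1. The two steps point the same way and cannot be told apart in size: the same change on two cores in this assay, a 2.3-fold lower number (0.35 log units; beyond the scatter) from compound 1 to compound 2 and a 4.9-fold lower number (0.69 log units; beyond the scatter) from compound 3 to compound 4, 2.2-fold (0.34 log units) apart, within the scatter of two such steps. Among these compounds, this shows that the change carried over between these two cores in direction and, within the scatter, in size, but it rests on only two pairs, so it does not show that the change would carry to any other core, does not explain why the number falls, and gives no ground for reading the larger step on the core of compound 3 as a real gain.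

The compounds shown leave open whether ethyl or a longer chain on the same amide nitrogen would give a step like that of methyl. They also leave open whether the step would survive on either core if an amine or a carboxylic acid stood in place of one trifluoromethyl group.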